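Swapping the Aryl Group on a Shared Core

The compounds below may be only part of what the source reports. "The series", "measured", "known", "first", "only" and "open" are said of these compounds alone.

Compound 1 `Cc1ccc(NC(=O)Nc2nnc(Sc3ncnc4scc(-c5ccncc5)c34)s2)cc1Cl` gives 34800 nM in a functional assay on T47D cells (Homo sapiens) for antiproliferative activity, read by MTT assay, with a stated time of 48 h; on this read-out higher numbers stand for weaker inhibition and lower numbers for stronger inhibition.
Compound 2 `Cc1ccc(NC(=O)Nc2nnc(Sc3ncnc4scc(-c5ccncc5)c34)s2)cc1` gives 17800 nM in this assay.
Compound 3 `O=C(Nc1ccc(Cl)c(Cl)c1)Nc1nnc(Sc2ncnc3scc(-c4ccncc4)c23)s1` gives 14600 nM in this assay.

Compound 1 holds the highest of the three numbers; the nearest is a 2.0-fold lower number from compound 1 to compound 2 (0.29 log units; within the scatter), and the furthest is a 2.4-fold lower number from compound 1 to compound 3 (0.38 log units; beyond the scatter). Compound 4 `O=C(Nc1cccc(F)c1)Nc1nnc(Sc2ncnc3scc(-c4ccncc4)c23)s1` differs from compound 1 in one place: 3-fluorophenyl in place of 3-chloro-4-methylphenyl on an amide-type nitrogen. Both measured steps bear on this change, since each alters the same aryl group, and each lowered the number only slightly. Compound 4 is therefore expected to sit somewhat below compound 1, with a 1.8-fold lower number from compound 1 to compound 4 (0.26 log units; within the scatter) expected to be a modest downward step that may not exceed the scatter. The estimate for compound 4 in this assay is 19000 nM, within a range from 7500 nM to 48000 nM.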

Compound 4, half-maximal inhibitory concentration: 16700 nM
The estimate for compound 4 lay 1.1-fold (0.06 log units) above the measured number; the measured number falls inside the stated range.
By their numbers in this assay, from the lowest: compounds 3, 4, 2 and 1 (each within the scatter of the next, the first and the last beyond it).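

Replacing 3-chloro-4-methylphenyl with 3-fluorophenyl gives a 2.1-fold lower number from compound 1 to compound 4 (0.32 log units; beyond the scatter), a modest step just past the scatter. Compound 4 cannot be separated from the other two aryl variants: a 1.1-fold higher number from compound 3 to compound 4 (0.06 log units; within the scatter) and a 1.1-fold lower number from compound 2 to compound 4 (0.03 log units; within the scatter) both stay within the scatter, so compounds 2, 3 and 4 form one group of similar numbers. No evidence is available to account for this.

All these aryl groups carry only halogen or methyl substituents. From the compounds shown here alone, whether an amine or a carboxylic acid on that ring, or a longer chain on the amide-type nitrogen, would move the number remains open.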